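Removing the (1-bromoethenyl)carbonyl group from compound 2

A few compounds are considered here, and "the series" means these few. Any claim that something is new, unique, unknown or untested is made for them only; others in the source may bear on it.

Measured in a functional assay on MOLT-4 cells (Homo sapiens) for antiproliferative activity, with a stated time of 48 h; a lower number here means a stronger inhibitor, a higher number a weaker inhibitor:
- compound 1 `C=C(Br)C(=O)Nc1ccc(C(=O)/C=C/c2cccc(OC)c2)cc1` gives 1100 nM
- compound 2 `C=C(Br)C(=O)Nc1ccc(C(=O)/C=C/c2cc(OC)cc(OC)c2)cc1` gives 1500 nM
- compound 3 `C=C(Br)C(=O)Nc1ccc(C(=O)/C=C/c2cc(OC)c(OC)c(OC)c2)cc1` gives 280 nM

Compound 2 stands at the upper end of these numbers, and the measured steps around it are a 1.4-fold higher number from compound 1 to compound 2 (0.13 log units; within the scatter) and a 5.4-fold lower number from compound 2 to compound 3 (0.73 log units; beyond the scatter). Compound 4 `COc1cc(/C=C/C(=O)c2ccc(N)cc2)cc(OC)c1` is still unmeasured. It has hydrogen in place of (1-bromoethenyl)carbonyl on a nitrogen on an aromatic ring, which turns ((1-bromoethenyl)carbonyl)amino into amino: hydrogen in place of (1-bromoethenyl)carbonyl on a nitrogen on an aromatic ring.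

Neither measured step speaks directly to this change. Both are methoxy in place of hydrogen on an aromatic carbon, and all three measured compounds keep the (1-bromoethenyl)carbonyl group, so the data hold no measure of its removal. On judgement, a move to a higher number is expected in this assay, beyond the scatter and probably larger than a 5.4-fold lower number from compound 2 to compound 3 (0.73 log units; beyond the scatter) in size. The estimated change is a 6.0-fold higher number from compound 2 to compound 4 (0.78 log units; beyond the scatter), with wide uncertainty. Among the measured compounds shown here, for compound 4 the expected value is 9000 nM, with an estimated range from 3000 nM to 30000 nM and no closer analogue to narrow it.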

Compound 4, half-maximal inhibitory concentration: 7500 nM
Estimate against measurement, compound 4: 1.2-fold (0.08 log units) above, within the range that was stated.
By their numbers in this assay, from the lowest: compound 3; then compounds 1 and 2 (each within the scatter of the next); then compound 4.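

In this assay, among the compounds shown here, the step of a 5.0-fold higher number from compound 2 to compound 4 (0.70 log units; beyond the scatter) gives the first measure of this change on the nitrogen on an aromatic ring, where ((1-bromoethenyl)carbonyl)amino becomes amino. The (1-bromoethenyl)carbonyl group therefore matters to the number in this pair, yet it is not required for activity in the cells, since compound 4 still gives 7500 nM in this series. No supporting data bear on the origin of this step.

The compounds shown do not separate the contribution of the bromine from that of the rest of the group, a question that an ethenylcarbonyl or acetyl group on the same nitrogen would address. Going by these compounds, it also stays open whether the same removal from compound 3 or compound 1 gives a step of similar size.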